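A few compounds are considered here, and "the series" means these few. Any claim that something is new, unique, unknown or untested is made for them only; others in the source may bear on it.

Measured so far in a functional assay on HCT-15 cells (Homo sapiens) for cytotoxicity, read by CCK-8 assay; on this read-out higher numbers stand for weaker inhibition and lower numbers for stronger inhibition:

compound 1, `Oc1ccccc1-c1cc(-c2ccco2)cc(-c2ccccc2O)n1`; in this assay compound 1 gives > 50000 nM, which is a limit of the assay and not a number.
compound 2, `Oc1cccc(-c2cc(-c3ccco3)cc(-c3ccccc3O)n2)c1`; in this assay compound 2 gives > 50000 nM, again a limit of the assay rather than a number.

Compound 2 therefore stands at the top limit of the read-out, and so does the only other compound shown: both values sit at the limit of > 50000 nM in this assay, at which 2 of the 2 values shown sit. Going by the values given here, the one measured step, a step that the two limits leave unreadable from compound 1 to compound 2, is not readable in size or direction, since both ends are limits.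

Compound 3, `Oc1ccc(-c2cc(-c3ccco3)cc(-c3ccccc3O)n2)cc1`, differs from compound 2 by 4-hydroxyphenyl in place of 3-hydroxyphenyl on an aromatic carbon. Among the compounds with values here, the only measured step that bears on this change is the unreadable one between compound 1 and compound 2, so no size or direction can be drawn from it. With both measured compounds at the limit, compound 3 is expected to stay there as well, the step that the limit leaves unreadable from compound 2 to compound 3 being expected to show nothing beyond the scatter. For compound 3 the estimate in this assay is 80000 nM, in a range of 30000 nM to 300000 nM, most likely reported only as a limit.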

Compound 3, half-maximal inhibitory concentration: > 50000 nM
Compound 3 ended at the assay's limit; the forecaster's own chance of this, stated with the estimate: 85%; the middle value lies beyond the limit too.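

In this assay no new step can be read among compound 1, compound 2 and compound 3, since each value is a limit of the assay and not a number: the limit of > 50000 nM in this assay, at which 3 of the 3 values shown sit.

The compounds shown leave open whether 2-hydroxyphenyl, 3-hydroxyphenyl and 4-hydroxyphenyl differ at all in this assay, and which change to the shared core would bring a value inside the limit.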